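A few compounds are considered here, and "the series" means these few. Any claim that something is new, unique, unknown or untested is made for them only; others in the source may bear on it.

In a functional assay on HepG2 cells (Homo sapiens) for antiproliferative activity, read by MTT assay, with a stated time of 48 h (a higher number here means a weaker inhibitor, a lower number a stronger inhibitor), three compounds sharing one core have been measured. Compound 1 `O=[N+]([O-])c1cccc(CSc2nnc(-c3ccc4c(c3)OCCO4)o2)c1` gives 38300 nM, compound 2 `Cc1ccccc1CSc1nnc(-c2ccc3c(c2)OCCO3)o1` gives 22000 nM, and compound 3 `Brc1ccccc1CSc1nnc(-c2ccc3c(c2)OCCO3)o1` gives 20000 nM. Compound 3 therefore stands level with both of the others, since its value lies within the usual scatter of each, and the data do not separate it from either one.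

The next compound is compound 4 `Clc1ccccc1CSc1nnc(-c2ccc3c(c2)OCCO3)o1`, which carries chloro in place of bromo on an aromatic carbon, turning the 2-bromobenzyl group into a 2-chlorobenzyl group: chloro in place of bromo on an aromatic carbon. For the measured compounds named here, one measured step bears on this change, a swap on the same aromatic carbon, a 1.1-fold lower number from compound 2 to compound 3 (0.04 log units; within the scatter). That swap of methyl for bromo stayed within the scatter, so no change beyond the scatter is expected in this assay from this further swap. The expected size is a 1.0-fold higher number from compound 3 to compound 4 (0.01 log units; within the scatter), which is no real shift in either direction. For compound 4 the estimated value is 20500 nM, with an expected range from 10000 nM to 40000 nM.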

Compound 4, half-maximal inhibitory concentration: 22600 nM
Beside the measured number, compound 4's estimate is 1.1-fold (0.04 log units) below it; the measured number falls inside the stated range.
By their numbers in this assay, from the lowest: compounds 3, 2, 4 and 1 (each within the scatter of the next).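

In this assay, the 2-bromobenzyl and 2-chlorobenzyl groups cannot be told apart: a 1.1-fold higher number from compound 3 to compound 4 (0.05 log units; within the scatter) lies within the scatter, and so does a 1.0-fold higher number from compound 2 to compound 4 (0.01 log units; within the scatter), which puts chloro in place of methyl on the same aromatic carbon. For the compounds shown here, with methyl, bromo and chloro now compared at this place, ortho to a large group, none of the three swaps among them moves the number beyond the scatter, whereas the earlier compounds offered only one such comparison. No measurement at hand accounts for why these three groups read alike.

The compounds shown leave open whether a group of another kind on this aromatic carbon, such as an amine, a carboxylic acid or a methoxy group, would shift the number beyond the scatter. They also leave open whether any change elsewhere on the shared core would do so.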